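This account rests on a few compounds, and the source may have more. Where it says the series, first, only, none or still open, it means among the compounds named here.

Compound 1, whose structure is `COc1cc(CNC(=O)/C=C/c2ccccc2)ccc1O`, is the simplest of the four compounds here. In a functional assay on SH-SY5Y cells (Homo sapiens) for cytotoxicity, read by MTT assay, with stated times of 24 h and 4 h (a lower number here means that less compound is needed, a higher number that more compound is needed for the effect), compound 1 gives 3660 nM. Compound 2, with structure `COc1cc(CNC(=O)/C=C/c2ccccc2)ccc1OCc1nc(C)c(C)nc1C`, differs from it by one change: (3,5,6-trimethylpyrazin-2-yl)methyl in place of hydrogen on an oxygen on an aromatic ring. In this assay compound 2 gives 7310 nM, and the step from compound 1 to compound 2 reads a 2.0-fold higher number from compound 1 to compound 2 (0.30 log units; within the scatter).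

Compound 3, whose structure is `COc1cc(CNC(=O)/C=C/c2cccc(OC)c2OC)ccc1O`, has a different core from compound 1; the difference between the two cores is not broken down here. In this assay compound 3 gives 5490 nM.

Compound 4, with structure `COc1cc(CNC(=O)/C=C/c2cccc(OC)c2OC)ccc1OCc1nc(C)c(C)nc1C`, has not yet been measured. It differs from compound 3 by the same change that separates compound 1 from compound 2: (3,5,6-trimethylpyrazin-2-yl)methyl in place of hydrogen on an oxygen on an aromatic ring. Among the measured compounds shown here, since the place of the change is the same in both pairs, the one measured step is the only guide available. Because that step came out as a 2.0-fold higher number from compound 1 to compound 2 (0.30 log units; within the scatter), a step of similar size is expected here, namely a 2.0-fold higher number from compound 3 to compound 4 (0.30 log units; within the scatter). Compound 4 is therefore estimated to give about 11000 nM in this assay, most likely somewhere between 5000 nM and 25000 nM.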

Compound 4, half-maximal effective concentration: 7150 nM
Beside the measured number, compound 4's estimate is 1.5-fold (0.19 log units) above it; low and high end bracket the measured number.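

In this assay the new step for the change reads a 1.3-fold higher number from compound 3 to compound 4 (0.11 log units; within the scatter), and the step between the two cores that both carry the (3,5,6-trimethylpyrazin-2-yl)methoxy group reads a 1.0-fold lower number from compound 2 to compound 4 (0.01 log units; within the scatter). Set side by side, the two steps for the same change agree as closely as measurements of this kind can show: the same change on two cores in this assay, a 2.0-fold higher number (0.30 log units; within the scatter) from compound 1 to compound 2 and a 1.3-fold higher number (0.11 log units; within the scatter) from compound 3 to compound 4, 1.5-fold (0.19 log units) apart, within the scatter of two such steps

This means that nothing here separates the behaviour of the change on one core from its behaviour on the other, but every step is within the scatter, so the change is not shown to have a real effect on either core, and two cores cannot establish a rule for the whole series.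

The compounds shown leave open what other groups on the same oxygen would do, such as a plain methyl or a longer chain ending in an amine. They also leave open whether the change would behave alike on a core with a carboxylic acid or a nitrile on the phenyl ring.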